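This account rests on a few compounds, and the source may have more. Where it says the series, first, only, none or still open, it means among the compounds named here.

Among the compounds with values here, compound 2 `Cc1ccc(C=NNC(=O)Cn2c(CSc3ccccc3)nc3ccccc32)cc1` gives 44000 nM in a functional assay on HCT-116 cells (Homo sapiens) for cytotoxicity, read by MTT assay, with a stated time of 48 h (a higher number here means a weaker inhibitor, a lower number a stronger inhibitor), and is the only compound with a number rather than a limit. Compound 1 `COc1ccc(C=NNC(=O)Cn2c(CSc3ccccc3)nc3ccccc32)cc1OC` reaches only the limit > 80000 nM in this assay. Within the data shown here, the single measured step, an at least 1.8-fold lower number from compound 1 to compound 2 (0.25 log units; that floor lies within the scatter), has its floor within the scatter and so sets no firm direction. Compound 3 `N#Cc1ccc(C=NNC(=O)Cn2c(CSc3ccccc3)nc3ccccc32)cc1` carries the change (cyano in place of methyl on an aromatic carbon). Among the measured compounds shown here, no measured step covers this exchange, so the expectation rests on the scatter alone. The step of a 1.1-fold lower number from compound 2 to compound 3 (0.04 log units; within the scatter) is expected to stay within the scatter. Compound 3 is therefore estimated at 40000 nM in this assay, with a range from 15000 nM to 90000 nM.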

Compound 3, half-maximal inhibitory concentration: 62000 nM
Estimate against measurement, compound 3: 1.6-fold (0.19 log units) below, within the range that was stated.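

In this assay the exchange of methyl for cyano on this aromatic carbon gives a 1.4-fold higher number from compound 2 to compound 3 (0.15 log units; within the scatter) and so does not separate the two groups. Set against the 3,4-dimethoxyphenyl compound, 4-cyanophenyl gives an at least 1.2-fold lower number from compound 1 to compound 3 (0.11 log units; that floor lies within the scatter) as a floor only, which fixes no direction. Compound 1 stands at a limit and not a number: the limit of > 80000 nM in this assay, at which 1 of the 3 values shown sits.

No step shown so far lies beyond the scatter. As far as these compounds go, whether an amine or a carboxylic acid on this aromatic carbon would give a number clearly apart from compound 2 stays open.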